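A few compounds are considered here, and "the series" means these few. Any claim that something is new, unique, unknown or untested is made for them only; others in the source may bear on it.

Compound 1 `COc1ccc(C(=O)/C=C/c2ccc(Cl)cc2)c2c1C=CC(C)(C)O2`: > 10000 nM
Compound 2 `COc1ccc(C(=O)/C=C/c2ccc(O)cc2)c2c1C=CC(C)(C)O2`: > 10000 nM

In a functional assay on HCT-116 cells (Homo sapiens) for antiproliferative activity, read by MTT assay, with a stated time of 24 h (on this read-out higher numbers stand for weaker inhibition and lower numbers for stronger inhibition), compound 1 gives > 10000 nM, which is a limit of the assay and not a number. Compound 2 gives > 10000 nM, and this too is a limit. Compound 2 therefore stands with compound 1 at the same limit: the limit of > 10000 nM in this assay, at which 2 of the 2 values shown sit. Within the data shown here, the only measured step, in which hydroxy takes the place of chloro on an aromatic carbon, is a step that the two limits leave unreadable from compound 1 to compound 2.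

Compound 3 `CCOc1cc(/C=C/C(=O)c2ccc(OC)c3c2OC(C)(C)C=C3)ccc1O` differs from compound 2 by ethoxy in place of hydrogen on an aromatic carbon. The new ethoxy sits ortho to a hydroxy group. The measured step has no readable size to carry over, so no clear move in either direction is expected in this assay. The expected step is a step that the limit leaves unreadable from compound 2 to compound 3. For compound 3 the estimated value is 12000 nM, with an expected range from 3000 nM to 30000 nM.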

Compound 3, half-maximal inhibitory concentration: > 10000 nM
Compound 3: a limit, no number (the forecaster's own chance of this, stated with the estimate: 65%); the middle value does not contradict the limit.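

Compound 3 gives > 10000 nM in this assay as a limit of the assay and not a number. Among these compounds, no step from compound 2 to compound 3 can therefore be read: the limit of > 10000 nM in this assay, at which 3 of the 3 values shown sit. The compounds shown leave open how strongly any of them acts on these cells, and whether chloro, hydroxy or ethoxy makes any difference.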